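The compounds below may be only part of what the source reports. "The series", "measured", "known", "first", "only" and "open" are said of these compounds alone.

Compound 2 `O=C(N[C@H]1CCC[C@H](NC(=O)c2ccccn2)C1)c1cccc(Cl)c1` belongs to a short series of amides tested in a functional assay on HEK293 cells for antagonist activity at metabotropic glutamate receptor 5 (Homo sapiens), read by FLIPR and calcium flux; on this read-out lower numbers stand for stronger inhibition and higher numbers for weaker inhibition. In this assay compound 2 reaches only the limit > 10000 nM, so no number is known for it. Compound 1 `O=C(N[C@H]1CCC[C@H](NC(=O)c2cnccn2)C1)c1cccc(Cl)c1` differs in the heteroaryl on the carbonyl carbon, and in this assay compound 1 gives 1370 nM. The step of an at least 7.2-fold higher number from compound 1 to compound 2 (0.86 log units; beyond the scatter) shows that swapping these six-membered rings moves the read-out, with one of the two values sitting at the limit of > 10000 nM in this assay, at which 1 of the 2 values shown sits. Compound 3 `O=C(N[C@H]1CCC[C@H](NC(=O)c2cccc(Cl)c2)C1)c1ccncc1` carries pyridin-4-yl in place of pyridin-2-yl on a carbonyl carbon. With compound 2 at a limit, the step of an at least 2.0-fold lower number from compound 2 to compound 3 (0.30 log units; that floor lies within the scatter) is expected only loosely. Compound 3 is estimated at 5000 nM, between 1200 nM and 20000 nM.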

Compound 3, half-maximal inhibitory concentration: 300 nM
Compound 3: middle estimate off by 17-fold (1.22 log units), on the high side; measured number below the stated range.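

The groups pyridin-2-yl and pyridin-4-yl have the same atoms and the same counts, yet this assay gives an at least 33-fold lower number from compound 2 to compound 3 (1.52 log units; beyond the scatter), so on this carbonyl carbon the way the ring is joined moves the read-out, not its composition alone. Pyridin-4-yl also gives a lower number than pyrazin-2-yl, with a 4.6-fold lower number from compound 1 to compound 3 (0.66 log units; beyond the scatter). The entry for compound 2 is a limit and not a number, so the first step gives only a floor: the limit of > 10000 nM in this assay, at which 1 of the 3 values shown sits.

Open, going by these compounds, is how pyridin-3-yl or a plain phenyl ring on this carbonyl carbon would read. Also open, on these data alone, is whether an amine or a methyl group on the pyridin-4-yl ring would keep the lower number.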